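Aryl swaps on a shared core, toward compound 4

The source may report more compounds than this note shows. Statements on the series, on what has been measured and on what is new or still open speak of the compounds shown alone.

- compound 1 `CC1(C)[C@H]2CC[C@]1(C)N(Cc1cn(-c3ccccc3Br)nn1)C(=O)C2` gives 500 nM
- compound 2 `Cc1ccc(-n2cc(CN3C(=O)C[C@@H]4CC[C@@]3(C)C4(C)C)nn2)cc1` gives 390 nM
- compound 3 `Cc1ccccc1-n1cc(CN2C(=O)C[C@@H]3CC[C@@]2(C)C3(C)C)nn1` gives 350 nM

In a functional assay on SGC-7901 cells (Homo sapiens) for inhibition, read by MTT assay, with a stated time of 24 h (a lower number here means a stronger inhibitor, a higher number a weaker inhibitor), compound 3 gives 350 nM and is not separated from the other two compounds, as every step among the three stays within the scatter.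

The change under consideration is 4-chlorophenyl in place of 2-methylphenyl on an aromatic nitrogen and it leads to compound 4 `CC1(C)[C@H]2CC[C@]1(C)N(Cc1cn(-c3ccc(Cl)cc3)nn1)C(=O)C2` with 4-chlorophenyl in place of 2-methylphenyl on an aromatic nitrogen. Among the compounds with values here, three measured steps bear on it. The swap of 4-methylphenyl for 2-methylphenyl gave a 1.1-fold lower number from compound 2 to compound 3 (0.05 log units; within the scatter) and methyl in place of bromo gave a 1.4-fold lower number from compound 1 to compound 3 (0.15 log units; within the scatter) while 4-methylphenyl in place of 2-bromophenyl gave a 1.3-fold lower number from compound 1 to compound 2 (0.11 log units; within the scatter) as its result. Within the data shown here, no 4-chlorophenyl compound has been measured yet, so this evidence is indirect. All three changes of the group on this nitrogen stayed small, so no step beyond the scatter is expected. Going by these compounds, the expected change is a 1.1-fold higher number from compound 3 to compound 4 (0.06 log units; within the scatter) in this assay and its direction remains open. The estimate for compound 4 is 400 nM within an expected range of 190 nM to 800 nM for repeated measurements.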

Compound 4, half-maximal inhibitory concentration: 410 nM
Beside the measured number, compound 4's estimate is 1.0-fold (0.01 log units) below it; the range from low to high includes it.
By their numbers in this assay, from the lowest: compounds 3, 2, 4 and 1 (each within the scatter of the next).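

In this assay, the 4-chlorophenyl group on the aromatic nitrogen is not separated from the 2-methylphenyl group, a 1.2-fold higher number from compound 3 to compound 4 (0.07 log units; within the scatter), from the 4-methylphenyl group with chloro in place of methyl, a 1.1-fold higher number from compound 2 to compound 4 (0.02 log units; within the scatter), or from the 2-bromophenyl group, a 1.2-fold lower number from compound 1 to compound 4 (0.09 log units; within the scatter). A chlorine on this aryl ring thus joins bromo and methyl as a substituent that gives no step beyond the scatter, so the flat picture across these aryl groups now holds for all four compounds. Nothing available explains this flatness, and no supporting data bear on it.

Still open, going by these compounds, is whether an aryl ring carrying an amine or a carboxylic acid would leave the scatter. The same applies to a longer alkyl chain in place of the aryl group on this nitrogen.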